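Changing the Amide Group on a Shared Core

The source may report more compounds than this note shows. Statements on the series, on what has been measured and on what is new or still open speak of the compounds shown alone.

Of the compounds shown here, three sharing one core have been measured in a functional assay on A549 cells (Homo sapiens) for inhibition, read by sulforhodamine B assay, with a stated time of 72 h (a lower number here means a stronger inhibitor, a higher number a weaker inhibitor), and they differ only in the group on the amide-type nitrogen. Compound 1 `Nc1sc(-c2ccc(Cl)cc2)c(-c2ccc(Cl)cc2)c1C(=O)NC1CCC1`, with cyclobutyl, gives 12500 nM. Compound 2 `CCCCNC(=O)c1c(N)sc(-c2ccc(Cl)cc2)c1-c1ccc(Cl)cc1`, with butyl, gives 8170 nM. Compound 3 `CC(C)(C)NC(=O)c1c(N)sc(-c2ccc(Cl)cc2)c1-c1ccc(Cl)cc1`, with tert-butyl, gives 8850 nM, which lies within the usual scatter of both other values.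

The next compound is compound 4 `Nc1sc(-c2ccc(Cl)cc2)c(-c2ccc(Cl)cc2)c1C(=O)NC1CCCC1`, which has cyclopentyl in place of tert-butyl on the amide-type nitrogen: cyclopentyl in place of tert-butyl on an amide-type nitrogen.

All three measured steps bear on this change, since each swaps one carbon-only group for another at that same place. They are a 1.5-fold lower number from compound 1 to compound 2 (0.18 log units; within the scatter), a 1.4-fold lower number from compound 1 to compound 3 (0.15 log units; within the scatter) and a 1.1-fold higher number from compound 2 to compound 3 (0.03 log units; within the scatter). None of them goes beyond the scatter, whether the group is a ring, a straight chain or tert-butyl. The step to cyclobutyl is the closest guide, as it also involves a carbon-only ring, and it too stays small. No step beyond the scatter is therefore expected in this assay, and no direction can be favoured. The expected change is a 1.1-fold higher number from compound 3 to compound 4 (0.03 log units; within the scatter). For compound 4 the estimated value is 9500 nM. The expected range for compound 4 runs from 5000 nM to 17000 nM.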

Compound 4, half-maximal inhibitory concentration: 6790 nM
The estimate for compound 4 lay 1.4-fold (0.15 log units) above the measured number; measured number inside the range.
By their numbers in this assay, from the lowest: compounds 4, 2, 3 and 1 (each within the scatter of the next).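

In this assay, cyclopentyl brings a five-membered carbon-only ring onto the amide-type nitrogen, and the steps to it from all three earlier groups stay within the scatter: from tert-butyl (a 1.3-fold lower number from compound 3 to compound 4 (0.12 log units; within the scatter)), from butyl (a 1.2-fold lower number from compound 2 to compound 4 (0.08 log units; within the scatter)) and from cyclobutyl (a 1.8-fold lower number from compound 1 to compound 4 (0.27 log units; within the scatter)). Within the data shown here, the last of these swaps one carbon-only ring for another, a kind of change the earlier compounds could not show, and it too stays within the scatter, so the two rings, the straight chain and tert-butyl cannot be told apart in this assay. Nothing available offers an explanation for this flat result.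

As far as these compounds go, all four groups contain carbon only, so it remains open whether a hydroxyl group, an amine, a carboxylic acid, a phenyl ring or a much longer chain on this nitrogen would move the number beyond the scatter. The rest of the shared core is the same in all four compounds, so these results also leave open what a change elsewhere on the core would do.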